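This account rests on a few compounds, and the source may have more. Where it says the series, first, only, none or still open, it means among the compounds named here.

In a functional assay on NALM-6 cells (Homo sapiens) for cytotoxicity, read by luminescence and CellTiter-Glo, with a stated time of 3 days (on this read-out lower numbers stand for stronger inhibition and higher numbers for weaker inhibition), compound 1 `N#Cc1cc(Cl)ccc1NC(=O)c1ccc2cccnc2c1O` gives 280 nM, compound 2 `O=C(Nc1ccc(Cl)cc1Cl)c1ccc2cccnc2c1O` gives 450 nM and compound 3 `O=C(Nc1ccc(Cl)cc1)c1ccc2cccnc2c1O` gives 380 nM, so compound 2 stands within the scatter of both others. Compound 4 `N#Cc1ccc(NC(=O)c2ccc3cccnc3c2O)c(Cl)c1` differs from compound 2 by one change: cyano in place of chloro on an aromatic carbon, para to a large group. For the measured compounds named here, two measured steps bear on it: a 1.6-fold higher number from compound 1 to compound 2 (0.21 log units; within the scatter), the same exchange in reverse, though compound 1 carries its cyano elsewhere, and a 1.2-fold lower number from compound 2 to compound 3 (0.07 log units; within the scatter), the loss of a chloro. Both lie within the scatter, so no step beyond it is expected in this assay. The expected change is small, a 1.3-fold lower number from compound 2 to compound 4 (0.11 log units; within the scatter). The estimate for compound 4 is 350 nM, with an expected range from 150 nM to 800 nM.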

Compound 4, half-maximal inhibitory concentration: 420 nM
The estimate for compound 4 lay 1.2-fold (0.08 log units) below the measured number, within the range that was stated.
By their numbers in this assay, from the lowest: compounds 1, 3, 4 and 2 (each within the scatter of the next).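

In this assay, the step to cyano, a 1.1-fold lower number from compound 2 to compound 4 (0.03 log units; within the scatter), is the first change shown at the carbon para to a large group, as the earlier steps changed another place on that ring. With the chloro group meta to it kept, chloro and cyano at this carbon give numbers within the scatter of each other. Nothing shown gives a measured reason for this result.

The compounds shown leave open whether an amine, a carboxylic acid or a longer chain at this carbon would also stay within the scatter. They also leave open how cyano here would read without the chloro group meta to it.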